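The source may report more compounds than this note shows. Statements on the series, on what has been measured and on what is new or still open speak of the compounds shown alone.

Measured compounds in a functional assay on HCT-116 cells (Homo sapiens) for inhibition, read by sulforhodamine B assay, with a stated time of 48 h; on this read-out higher numbers stand for weaker inhibition of growth and lower numbers for stronger inhibition of growth:
Compound 1 `O=C(Nc1cccc(-n2cc(-c3ccncc3)c(-c3ccc(Cl)c(O)c3)n2)c1)Nc1ccc(Cl)c(Cl)c1` gives 5730 nM.
Compound 2 `COc1cc(-c2nn(-c3cccc(NC(=O)c4cccc(C(F)(F)F)c4)c3)cc2-c2ccncc2)ccc1Cl` gives only a limit, > 50000 nM.
Compound 3 `O=C(Nc1cccc(-n2cc(-c3ccncc3)c(-c3ccc(Cl)c(O)c3)n2)c1)Nc1cc(C(F)(F)F)cc(C(F)(F)F)c1` gives 1110 nM.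

Compound 2 stands at the limit of > 50000 nM in this assay, at which 1 of the 3 values shown sits, so no number is known for it, only that it is a limit. Compound 1 and compound 3, both carrying a urea on the aniline of the shared core, give measurable total growth inhibition in this assay, with compound 1 at 5730 nM and compound 3 at 1110 nM.

Compound 4 `COc1cc(-c2nn(-c3cccc(NC(=O)Nc4ccc(Cl)c(C(F)(F)F)c4)c3)cc2-c2ccncc2)ccc1Cl` differs from compound 2 in one place: (4-chloro-3-(trifluoromethyl)phenyl)amino in place of 3-(trifluoromethyl)phenyl on a carbonyl carbon. Because compound 2 sits at the limit of > 50000 nM in this assay, at which 1 of the 3 values shown sits, any measurable value for compound 4 would already mean a step toward stronger inhibition. The author expects compound 4 to behave more like the urea compounds 1 and 3 than like compound 2, with an estimated step of an at least 12-fold lower number from compound 2 to compound 4 (1.09 log units; beyond the scatter) in this assay. Compound 4 is therefore estimated at 4000 nM, with a range from 1000 nM to 25000 nM.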

Compound 4, concentration for total growth inhibition: 4560 nM
Estimate against measurement, compound 4: 1.1-fold (0.06 log units) below; measured number inside the range.
By their numbers in this assay, from the lowest: compound 3; then compounds 4 and 1 (each within the scatter of the next). At a limit, above all of these: compound 2.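

In this assay, (4-chloro-3-(trifluoromethyl)phenyl)amino in place of 3-(trifluoromethyl)phenyl on a carbonyl carbon gives an at least 10-fold lower number from compound 2 to compound 4 (1.04 log units; beyond the scatter). This is the first pair shown that differs in one place, and it ties the appearance of a measurable value to this single change on a carbonyl carbon whose other neighbour is an amide-type nitrogen. The size of the step is only a minimum, since one end of it is a limit and not a number: the limit of > 50000 nM in this assay, at which 1 of the 4 values shown sits.

The change brings in the amino nitrogen, with its hydrogen-bond donor, and the chlorine at once, and the compounds shown do not separate the two. Also open, on these data alone, is how a methylene in place of that nitrogen, or a fluorine in place of that chlorine, would read in this assay.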